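The source may hold more compounds than are shown below. What is called first, only, known or untested is meant among the compounds shown, and "the series" means these compounds.

Compound 2, with structure `CC(C)Oc1ccccc1N1CCN(Cc2nc(CN3CCCC3=O)co2)CC1`, is measured in an assay on isolated protein for displacement of a labelled ligand from Alpha-1A adrenergic receptor (Homo sapiens) (on this read-out lower numbers stand for stronger inhibition and higher numbers for weaker inhibition), where compound 2 gives 1300 nM. That is the higher of the two numbers available. The other measured compound, compound 1 with structure `O=C1CCCCN1Cc1cc(CN2CCN(c3ccccc3Oc3ccccc3)CC2)on1`, gives 15 nM in this assay, and the two structures differ in several places at once, so the gap between them cannot be tied to any single change.

Compound 3, with structure `CC(C)Oc1ccccc1N1CCN(Cc2nc(CN3CCCCC3=O)co2)CC1`, is a single change away from compound 2: 2-oxopiperidin-1-yl in place of 2-oxopyrrolidin-1-yl on a saturated chain carbon bound to an aromatic carbon. Among the measured compounds shown here, no measured pair shows this change on its own, so the size of its effect is unknown. Compound 1 does carry the 2-oxopiperidin-1-yl group and gives a low number, but its other differences leave that hint weak. A modest step toward a lower number, a 2.6-fold lower number from compound 2 to compound 3 (0.41 log units; beyond the scatter), is expected. Compound 3 is estimated at 500 nM, within a range from 120 nM to 2000 nM.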

Compound 3, inhibition constant: 2320 nM
The estimate for compound 3 lay 4.6-fold (0.67 log units) below the measured number; measured number outside the range, above it.
By their numbers in this assay, from the lowest: compound 1; then compounds 2 and 3 (each within the scatter of the next).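

In this assay, putting 2-oxopiperidin-1-yl in place of 2-oxopyrrolidin-1-yl on a saturated chain carbon bound to an aromatic carbon gives a 1.8-fold higher number from compound 2 to compound 3 (0.25 log units; within the scatter) and so this pair shows no real effect of the change. On this core, the six-membered ring and the five-membered ring read alike, and the 2-oxopiperidin-1-yl group brings no measurable gain. Nothing available here explains this result.

Still open, on these data alone, is whether a different group on the same saturated chain carbon, such as an amine or a carboxylic acid, would shift the number beyond the scatter. It is also open whether the same swap would read alike on the core of compound 1, where no matching partner is shown.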